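The source may hold more compounds than are shown below. What is called first, only, known or untested is meant among the compounds shown, and "the series" means these compounds.

Going by the values given here, compound 1, whose structure is `CC(C)(C)C1=NN(c2ccc(Br)cc2)C(c2ccc(O)cc2)C1`, has the higher of the two numbers measured so far. In an assay on isolated protein for inhibition of protein kinase C zeta type (Homo sapiens), with a stated time of 4 min, tested at 62.5 uM (on this read-out higher numbers stand for more inhibition at the one concentration tested (going by the name of the read-out) and lower numbers for less inhibition), compound 1 gives 93.2%, the highest of the two numbers. Among the compounds with values here, its only neighbour, compound 2, with structure `CC(C)c1ccc(N2N=C(C(C)(C)C)CC2c2ccc(O)cc2)cc1`, gives 54.9% in this assay. Within the data shown here, the single measured step, a number 38.3 percentage points lower from compound 1 to compound 2 (beyond the scatter), comes from swapping isopropyl in place of bromo on an aromatic carbon, and it is large and well beyond the scatter.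

Compound 3, with structure `CC(C)(C)C1=NN(c2ccc(C(=O)O)cc2)C(c2ccc(O)cc2)C1`, is not yet measured. It differs from compound 1 as follows: carboxy in place of bromo on an aromatic carbon. The bromo group of compound 1 is therefore again replaced at the same aromatic carbon, now by carboxy rather than by isopropyl. The measured step from compound 1 to compound 2 bears on this change only loosely, since the entering group differs, but it shows that changing the bromo group at this place can lower inhibition by a large amount. A drop is therefore expected for compound 3 as well, estimated at a number 31.2 percentage points lower from compound 1 to compound 3 (beyond the scatter), though its size is uncertain. The expected value for compound 3 in this assay is 62%, with a likely range from 28% to 92%.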

Compound 3, a percentage reported as inhibition, at one concentration (the size of the read-out at that concentration, not a potency): 47.9%
Compound 3: middle estimate off by 14.1 percentage points, on the high side, and the stated range covers the measured number.
By their numbers in this assay, from the lowest: compounds 3 and 2 (each within the scatter of the next); then compound 1.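

Replacing bromo at this aromatic carbon with carboxy also lowers the number in this assay (a number 45.3 percentage points lower from compound 1 to compound 3 (beyond the scatter)), so the loss seen with isopropyl is not limited to that one entering group. The two entering groups differ in make-up, since carboxy brings a hydrogen-bond donor and acceptor and isopropyl is a plain branched hydrocarbon group, yet the step between them is small (a number 7 percentage points lower from compound 2 to compound 3 (within the scatter)), so this assay does not separate compound 2 from compound 3. Among these three compounds, only the one with bromo reaches the high number, but no measurement shown explains what sets bromo apart.

Going by these compounds, it remains open whether the high number belongs to bromo alone or would also appear with another halogen, such as chlorine or fluorine, at this place. The compounds shown also leave open how an amine, a methoxy group or a plain hydrogen here would compare, and so whether the other entering groups would fall with carboxy and isopropyl or stay with bromo.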